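Trading Two Fluorines for One Chlorine on the Benzyl Group

The compounds below may be only part of what the source reports. "The series", "measured", "known", "first", "only" and "open" are said of these compounds alone.

Three measured compounds share one core and differ only in the ring carried by the benzyl ether. Compound 1 `Cc1cc(C(=O)O)nn1Cc1cc(Br)ccc1OCc1ccc(Cl)cc1`, tested in a functional assay on CHO-K1 cells for antagonist activity at prostaglandin E2 receptor EP1 subtype (Homo sapiens), read by FLIPR (a lower number here means a stronger inhibitor, a higher number a weaker inhibitor), gives 8.71 nM. Compound 2 `Cc1cc(C(=O)O)nn1Cc1cc(Br)ccc1OCc1ccc(F)cc1` gives 11.8 nM in this assay, and the step between them, a 1.4-fold higher number from compound 1 to compound 2 (0.13 log units; within the scatter), is small. Compound 3 `Cc1cc(C(=O)O)nn1Cc1cc(Br)ccc1OCc1c(F)cccc1F` gives 105 nM, the highest number of the three; the steps of a 12-fold higher number from compound 1 to compound 3 (1.08 log units; beyond the scatter) and an 8.9-fold higher number from compound 2 to compound 3 (0.95 log units; beyond the scatter) are both clearly beyond the scatter. Compound 4 `Cc1cc(C(=O)O)nn1Cc1cc(Br)ccc1OCc1cccc(Cl)c1` is not yet measured; it differs from compound 3 by 3-chlorophenyl in place of 2,6-difluorophenyl on a saturated chain carbon bound to an oxygen on an aromatic ring. The two large steps bear on this change: each put two fluorines on the ring in place of a single halogen and each raised the number considerably. Compound 4 returns to a single halogen, a chlorine as in compound 1, though no measurement exists for the 3-chlorophenyl arrangement itself. For compound 4 a substantial fall in the number is therefore expected, a 7.0-fold lower number from compound 3 to compound 4 (0.85 log units; beyond the scatter), with wide uncertainty. Compound 4 is estimated at 15 nM, with a range from 5 nM to 60 nM.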

Compound 4, inhibition constant: 427 nM
The estimate for compound 4 lay 28-fold (1.45 log units) below the measured number; the whole stated range lies below it.
By their numbers in this assay, from the lowest: compounds 1 and 2 (each within the scatter of the next); then compound 3; then compound 4.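

Where the chlorine sits on the benzyl ring matters here: 3-chlorophenyl and 4-chlorophenyl carry the same atoms, yet this assay gives a 49-fold higher number from compound 1 to compound 4 (1.69 log units; beyond the scatter). Single-halogen rings therefore do not form one group, as 3-chlorophenyl also compares poorly with 4-fluorophenyl, with a 36-fold higher number from compound 2 to compound 4 (1.56 log units; beyond the scatter), and even with 2,6-difluorophenyl, with a 4.1-fold higher number from compound 3 to compound 4 (0.61 log units; beyond the scatter), so the number of halogens alone does not set the order of these compounds. Nothing available explains why these rings differ so much.

Still open, from the compounds shown here alone, is whether the weak result of compound 4 belongs to chlorine itself or to any group in that place on the ring. A methyl or methoxy group in place of the chlorine of compound 4 would address that question.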